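A few compounds are considered here, and "the series" means these few. Any claim that something is new, unique, unknown or untested is made for them only; others in the source may bear on it.

Three compounds have so far been examined in an ADME assay on C8166 cells (Homo sapiens) for cytotoxicity, read by colorimetric assay and MTT assay; a higher number here means that more compound is tolerated, a lower number that less compound is tolerated. Compound 1 `Cc1cc(C)cc(C(=O)c2c(OCC(=O)Nc3ccc(S(N)(=O)=O)cc3C)ccc3cc(Br)ccc23)c1` gives 24500 nM in this assay. Compound 2 `Cc1ccc(C(=O)c2c(OCC(=O)Nc3ccc(S(N)(=O)=O)cc3C)ccc3cc(Br)ccc23)cc1C` gives 85200 nM in this assay. For compound 3 `Cc1ccc(C(=O)c2c(OCC(=O)Nc3ccc(S(N)(=O)=O)cc3C)ccc3cc(C#N)ccc23)cc1C` the reading of > 379000 nM in this assay is a limit of the assay rather than a number. Among the measured compounds shown here, compound 3 is the one compound whose value sits at the limit of > 379000 nM in this assay, at which 1 of the 3 values shown sits.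

Two changes tie these compounds together. Compound 1 differs from compound 2 by 3,5-dimethylphenyl in place of 3,4-dimethylphenyl on a carbonyl carbon, and this change brings a 3.5-fold lower number from compound 2 to compound 1 (0.54 log units; beyond the scatter). Compound 3 differs from compound 2 in the core, by cyano in place of bromo on an aromatic carbon, and that change brings an at least 4.4-fold higher number from compound 2 to compound 3 (0.64 log units; beyond the scatter).

Compound 4 `Cc1cc(C)cc(C(=O)c2c(OCC(=O)Nc3ccc(S(N)(=O)=O)cc3C)ccc3cc(C#N)ccc23)c1` has not yet been measured in this assay. It differs from compound 3 by 3,5-dimethylphenyl in place of 3,4-dimethylphenyl on a carbonyl carbon, the same change as that between compound 2 and compound 1. The step is estimated to read an at least 1.8-fold lower number from compound 3 to compound 4 (0.27 log units; that floor lies within the scatter), resting on a 3.5-fold lower number from compound 2 to compound 1 (0.54 log units; beyond the scatter) and on compound 3 having only a limit in this assay. Compound 4 is therefore expected to give about 200000 nM, most likely between 70000 nM and 600000 nM.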

Compound 4, half-maximal cytotoxic concentration: 128000 nM
Compound 4: the middle estimate sits 1.6-fold (0.19 log units) above what was measured; the range from low to high includes it.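

On the core bearing cyano, 3,5-dimethylphenyl in place of 3,4-dimethylphenyl on a carbonyl carbon in this assay gives an at least 2.9-fold lower number from compound 3 to compound 4 (0.47 log units; beyond the scatter), the same direction as on the core bearing bromo: the same change on two cores in this assay, a 3.5-fold lower number (0.54 log units; beyond the scatter) from compound 2 to compound 1 and an at least 2.9-fold lower number (0.47 log units; beyond the scatter) from compound 3 to compound 4; the limit leaves it open whether they differ. Cyano in place of bromo likewise keeps its direction when carried to the other aryl ketone, giving a 5.2-fold higher number from compound 1 to compound 4 (0.72 log units; beyond the scatter): the same change on two cores in this assay, an at least 4.4-fold higher number (0.64 log units; beyond the scatter) from compound 2 to compound 3 and a 5.2-fold higher number (0.72 log units; beyond the scatter) from compound 1 to compound 4; the limit leaves it open whether they differ. Compound 3 reads > 379000 nM, a limit of the assay and not a number, and the two pairs of steps show a shared direction only, not a shared size.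

The compounds shown leave open whether the same aryl change would hold with a chlorine atom or a methoxy group in place of bromo or cyano, and how an unsubstituted phenyl on the carbonyl carbon would read. They also leave open how a carboxylic acid in place of the sulfonamide would read in this assay.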